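The compounds below may be only part of what the source reports. "The series", "measured", "known", "first", "only" and "open" are said of these compounds alone.

Measured in a functional assay on MCF7 cells (Homo sapiens) for inhibition, read by colorimetric assay and MTT assay, with a stated time of 72 h; a lower number here means a stronger inhibitor, a higher number a weaker inhibitor
- Compound 1 `Cc1ccc2c(c1)-c1cnc(n1C)OCCCCCCCCO2` gives 34000 nM
- Compound 2 `COc1ccc2c(c1)-c1cnc(n1C)OCCCCCCCCO2` gives 32000 nM

Compound 2 stands level with compound 1. The two numbers lie within the scatter of each other, so neither can be ranked above the other. Compound 3 `Cn1c2cnc1OCCCCCCCCOc1ccc(F)cc1-2` keeps the shared core and changes one group, with fluoro in place of methoxy on an aromatic carbon. Among the measured compounds shown here, only one measured step bears on this change, a swap on that same aromatic carbon, methoxy in place of methyl (a 1.1-fold lower number from compound 1 to compound 2 (0.03 log units; within the scatter)). For the measured compounds named here, that step stayed within the scatter, so the number barely responded to the one exchange tried at this place. Fluoro itself has not been measured in this series, and a single step is thin evidence. In this assay no step beyond the scatter is therefore expected, in either direction. The expected move (a 1.0-fold higher number from compound 2 to compound 3 (0.01 log units; within the scatter)) would be too small to read. Compound 3 is estimated at 33000 nM with an expected range from 16000 nM to 65000 nM in this assay for now.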

Compound 3, half-maximal inhibitory concentration: 52000 nM
Compound 3: the middle estimate sits 1.6-fold (0.20 log units) below what was measured; measured number inside the range.
By their numbers in this assay, from the lowest: compounds 2, 1 and 3 (each within the scatter of the next).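

In this assay, fluoro is a third group on this aromatic carbon, and the number still does not move beyond the scatter: a 1.6-fold higher number from compound 2 to compound 3 (0.21 log units; within the scatter), and a 1.5-fold higher number from compound 1 to compound 3 (0.18 log units; within the scatter). The earlier pair showed only that methoxy and methyl could not be told apart, whereas this result adds a group with a different atom at the point of attachment. Methoxy carries one hydrogen-bond acceptor and fluoro none, yet this exchange also gives no readable change, so across these three compounds the assay does not separate the groups tried at this place, and nothing measured on them offers an explanation for that flat response.

The compounds shown leave open whether a group of a different kind on this carbon, such as an amine or a carboxylic acid, would produce a step beyond the scatter. They also leave open whether a change elsewhere, such as a longer chain in place of the one that closes the shared core, would shift the number more than any exchange at this aromatic carbon has so far.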